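The compounds below may be only part of what the source reports. "The series", "measured", "known", "first", "only" and "open" are said of these compounds alone.

Series notes, inhibition of prostate steroid reductase

- compound 1 `CCCn1ccc2cc(/C(C)=C/C(=O)Nc3ccccc3OCCCC(=O)O)ccc21`: in an assay on Prostate gland for inhibition of steroid 5-alpha-reductase (Rattus norvegicus) (on this read-out lower numbers stand for stronger inhibition and higher numbers for weaker inhibition), compound 1 gives 190 nM
- compound 2 `CC(C)=CCn1ccc2cc(/C(C)=C/C(=O)Nc3ccccc3OCCCC(=O)O)ccc21`: in this assay compound 2 gives 120 nM
- compound 3 `C/C(=C\C(=O)Nc1ccccc1OCCCC(=O)O)c1ccc2c(ccn2C(C(C)C)C(C)C)c1`: in this assay compound 3 gives 14 nM

Compound 3 stands lowest of the three numbers. Its nearest neighbour is compound 2, an 8.6-fold lower number from compound 2 to compound 3 (0.93 log units; beyond the scatter); the furthest is compound 1, a 14-fold lower number from compound 1 to compound 3 (1.13 log units; beyond the scatter). Between compound 1 and compound 2 the step is a 1.6-fold lower number from compound 1 to compound 2 (0.20 log units; within the scatter), so only the change to the 1-isopropyl-2-methylpropyl group on the aromatic nitrogen has moved the read-out beyond the scatter in this set.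

Compound 4 `C/C(=C\C(=O)Nc1ccccc1OCCCC(=O)O)c1ccc2c(ccn2Cc2ccc(F)cc2)c1` differs from compound 3 at that same nitrogen: 4-fluorobenzyl in place of 1-isopropyl-2-methylpropyl on an aromatic nitrogen. For the measured compounds named here, no measured pair shows this group, so the only bearing steps are those into compound 3 from compound 1 and compound 2, both of which show that the substituent on this nitrogen can shift the read-out by a large margin. Compound 4 carries a group unlike any of the three measured ones, and the expectation is therefore set between the number of compound 3 and those of compound 1 and compound 2, with wide margins. The estimated step is a 3.2-fold higher number from compound 3 to compound 4 (0.51 log units; beyond the scatter). For compound 4 in this assay the estimate is 45 nM, expected to fall between 15 nM and 150 nM.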

Compound 4, half-maximal inhibitory concentration: 97 nM
Compound 4: the middle estimate sits 2.2-fold (0.33 log units) below what was measured, within the range that was stated.
By their numbers in this assay, from the lowest: compound 3; then compounds 4, 2 and 1 (each within the scatter of the next).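

On the aromatic nitrogen, a group carrying a six-membered aromatic ring now stands against the open-chain groups, and in this assay 4-fluorobenzyl does not match 1-isopropyl-2-methylpropyl: the series shows a 6.9-fold higher number from compound 3 to compound 4 (0.84 log units; beyond the scatter) for this change. Set against the other two groups, 4-fluorobenzyl gives a 1.2-fold lower number from compound 2 to compound 4 (0.09 log units; within the scatter) and a 2.0-fold lower number from compound 1 to compound 4 (0.29 log units; within the scatter) as its steps, both within the scatter, so compounds 1, 2 and 4 form one level despite their different groups, and among the four compounds only compound 3 stands apart, with no compound going against this. Nothing at hand accounts for the gap between compound 3 and the other three compounds.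

Still open, from the compounds shown here alone, is whether a cyclohexyl or a 1-ethylpropyl group on this nitrogen would read with compound 3 or with the level of compounds 1, 2 and 4. Also open, going by these compounds, is how an unsubstituted benzyl group would read against 4-fluorobenzyl at the same place, which would show whether the fluorine has any bearing on the number in this assay here.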